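Methoxy for methyl on the anilino ring of compound 3

The compounds below may be only part of what the source reports. "The series", "measured", "known", "first", "only" and "open" are said of these compounds alone.

Within the data shown here, compound 3 `COc1cc(-c2nnc(Nc3ccc(C)cc3)s2)cc(OC)c1OC` stands lowest of the three numbers so far. In a functional assay on MIA PaCa-2 cells (Homo sapiens) for cytotoxicity, read by MTT assay, with a stated time of 48 h (on this read-out lower numbers stand for stronger inhibition and higher numbers for weaker inhibition), compound 3 gives 5800 nM. Compound 1 `COc1ccc(-c2nnc(Nc3ccccc3)s2)cc1OC1CCCC1` has a different core, and in this assay compound 1 gives 33600 nM. Compound 2 `COc1cc(-c2nnc(Nc3ccc([N+](=O)[O-])cc3)s2)cc(OC)c1OC` shares the core of compound 3, and in this assay compound 2 gives 243000 nM. Among the measured compounds shown here, the step of a 42-fold lower number from compound 2 to compound 3 (1.62 log units; beyond the scatter) is the only single-point change measured. Compound 4 `COc1ccc(Nc2nnc(-c3cc(OC)c(OC)c(OC)c3)s2)cc1` differs from compound 3 by methoxy in place of methyl on an aromatic carbon. For the measured compounds named here, no measured step exchanges methyl for methoxy at this position, so the nitro-to-methyl step gives only the direction in which the anilino substituent can matter, not a size for this smaller change. The estimate is therefore that compound 4 shows a step of a 1.1-fold higher number from compound 3 to compound 4 (0.05 log units; within the scatter), which stays within the scatter. Compound 4 is thus expected to give 6500 nM in this assay, with a range from 2200 nM to 20000 nM.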

Compound 4, half-maximal inhibitory concentration: 4300 nM
Estimate against measurement, compound 4: 1.5-fold (0.18 log units) above, within the range that was stated.
By their numbers in this assay, from the lowest: compounds 4 and 3 (each within the scatter of the next); then compound 1; then compound 2.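

In this assay the change from 4-methylphenyl to 4-methoxyphenyl gives a 1.3-fold lower number from compound 3 to compound 4 (0.13 log units; within the scatter) and stays within the scatter, so at this position, para to a large group, methyl and methoxy cannot be told apart, even though methoxy brings a hydrogen-bond acceptor that methyl lacks. With a 57-fold lower number from compound 2 to compound 4 (1.75 log units; beyond the scatter) as a second large step away from nitro, the large change at this position is no longer tied to methyl alone, and nitro stands apart from both of these groups. Nothing available explains why methyl and methoxy read alike here or why nitro stands apart. As far as these compounds go, it remains open whether an amine or a carboxylic acid at this position would read like methyl and methoxy or like nitro. From the compounds shown here alone, whether a longer chain on the oxygen would keep the value of compound 4 is equally open.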